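Quinoline sulfone series: methoxy to fluoro on the sulfonyl aryl

The compounds below may be only part of what the source reports. "The series", "measured", "known", "first", "only" and "open" are said of these compounds alone.

Measured so far in an ADME assay on microsomes from liver (Homo sapiens) for metabolic stability, tested at 2.5 uM; on this read-out lower numbers stand for slow clearance and higher numbers for fast clearance:
compound 1 `COc1cccc(S(=O)(=O)c2cnc3cc(F)ccc3c2-c2cccc(Cl)c2)c1` gives 2.97 mL/min
compound 2 `O=S(=O)(c1cc(F)cc(F)c1)c1cnc2cc(F)ccc2c1-c1cccc(Cl)c1` gives 0.22 mL/min
compound 3 `COc1ccc(S(=O)(=O)c2cnc3cc(F)ccc3c2-c2cccc(Cl)c2)cc1Cl` gives 1.19 mL/min

Compound 3 stands second highest of the three in this assay, sitting between the others, as seen in a 2.5-fold lower number from compound 1 to compound 3 (0.40 log units; beyond the scatter) and a 5.4-fold higher number from compound 2 to compound 3 (0.73 log units; beyond the scatter). Compound 4 `O=S(=O)(c1ccc(F)c(Cl)c1)c1cnc2cc(F)ccc2c1-c1cccc(Cl)c1` is not yet measured. The change from compound 3 is fluoro in place of methoxy on an aromatic carbon.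

Going by the values given here, two measured steps bear on this. In a 14-fold lower number from compound 1 to compound 2 (1.13 log units; beyond the scatter) the aryl on the sulfonyl sulfur carrying fluoro rather than methoxy gave a much lower number, and a 5.4-fold higher number from compound 2 to compound 3 (0.73 log units; beyond the scatter) runs the other way when methoxy returns. Both point the same way, so a lower number for compound 4 is expected, estimated as the step of a 2.4-fold lower number from compound 3 to compound 4 (0.38 log units; beyond the scatter). Compound 4 is estimated at 0.5 mL/min in this assay, with a range from 0.22 mL/min to 1.2 mL/min.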

Compound 4, intrinsic clearance in a liver preparation (reported as CLH), per the amount of preparation that the assay uses: 0.66 mL/min
For compound 4 the middle estimate is 1.3-fold (0.12 log units) below the measured one, within the range that was stated.
By their numbers in this assay, from the lowest: compound 2; then compounds 4 and 3 (each within the scatter of the next); then compound 1.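

At this place, para to a large group and ortho to a chloro group, fluoro in place of methoxy leaves the number within the scatter (a 1.8-fold lower number from compound 3 to compound 4 (0.26 log units; within the scatter)), so this change is not resolved in this assay. The 3-chloro-4-fluorophenyl group still differs beyond the scatter from the other two aryl groups on the sulfonyl sulfur (a 3.0-fold higher number from compound 2 to compound 4 (0.48 log units; beyond the scatter); a 4.5-fold lower number from compound 1 to compound 4 (0.65 log units; beyond the scatter)). No measurement here accounts for these differences.

Still open, from the compounds shown here alone, is how an amine or a carboxylic acid at this place would read in this assay.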